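Amide substituents at the limit of the assay

This account rests on a few compounds, and the source may have more. Where it says the series, first, only, none or still open, it means among the compounds named here.

- compound 1 `COc1cc2nccc(Oc3ccc(Nc4nn(C)cc4C(=O)NCc4ccccc4)cc3)c2cc1C(N)=O`: > 10000 nM, a limit
- compound 2 `COc1cc2nccc(Oc3ccc(Nc4nn(C)cc4C(=O)NOCc4ccccc4)cc3)c2cc1C(N)=O`: > 10000 nM, a limit

In a functional assay on BaF3 cells (Mus musculus) for antiproliferative activity, read by CCK-8 assay and cell counting, with a stated time of 76 h (on this read-out lower numbers stand for stronger inhibition and higher numbers for weaker inhibition), compound 2 gives > 10000 nM, which is a limit and not a number. The two measured compounds share one position: the limit of > 10000 nM in this assay, at which 2 of the 2 values shown sit. Among the compounds with values here, the only measured step is a step that the two limits leave unreadable from compound 1 to compound 2, with benzyloxy in place of benzyl on an amide-type nitrogen.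

Compound 3 `COc1cc2nccc(Oc3ccc(Nc4nn(C)cc4C(=O)NC4CCCC4)cc3)c2cc1C(N)=O` carries cyclopentyl in place of benzyloxy on an amide-type nitrogen. Within the data shown here, no step of readable size bears on this change, so no clear shift in either direction is expected in this assay. The expectation rests on compound 1 and compound 2 sharing (the limit of > 10000 nM in this assay, at which 2 of the 2 values shown sit). The estimated step is a number no higher from compound 2 to compound 3 (the limit leaves the size open). Compound 3 is expected at 10000 nM, with an estimated range of 3000 nM to 30000 nM, and a further report of only a limit is the likeliest outcome.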

Compound 3, half-maximal inhibitory concentration: > 10000 nM
Compound 3 was reported as a limit (the forecaster's own chance of this, stated with the estimate: 75%); the middle value lies on the limit itself.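

No step can be read among compound 1, compound 2 and compound 3, as all three stand at the same limit in this assay: the limit of > 10000 nM in this assay, at which 3 of the 3 values shown sit.

Going by these compounds, how benzyl, benzyloxy and cyclopentyl rank on the amide nitrogen in this assay stays open, as does whether any substituent there gives a measurable value.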